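This account rests on a few compounds, and the source may have more. Where it says the series, first, only, none or still open, it means among the compounds named here.

Of the compounds shown here, three built on one shared core have been tested in a functional assay on MCF7 cells (Homo sapiens) for cytotoxicity, read by MTT assay, with a stated time of 72 h; a lower number here means a stronger inhibitor, a higher number a weaker inhibitor. Compound 1 `CNC(=O)c1cc(Oc2ccc(NC(=O)c3nccc(-c4ccc(OC)cc4)n3)cc2)ccn1` gives 35200 nM in this assay, a weak result. Compound 2 `CNC(=O)c1cc(Oc2ccc(NC(=O)c3cc(-c4ccc(F)cc4)ncn3)cc2)ccn1` reaches only the limit of this assay, reported as > 100000 nM. Compound 3 `CNC(=O)c1cc(Oc2ccc(NC(=O)c3cc(-c4ccc(C(F)(F)F)cc4)ncn3)cc2F)ccn1` likewise stops at the limit, > 100000 nM, so its standing is known only as a bound. That bound is the limit of > 100000 nM in this assay, at which 2 of the 3 values shown sit. Compound 4 `CCc1ccc(-c2cc(C(=O)Nc3ccc(Oc4ccnc(C(=O)NC)c4)c(F)c3)ncn2)cc1` differs from compound 3 in one place: ethyl in place of trifluoromethyl on an aromatic carbon. For the measured compounds named here, no measured pair showing this same change exists here, so the outcome rests on the change alone. The expected step is a number no higher from compound 3 to compound 4 (the limit leaves the size open), nothing beyond the usual scatter. Compound 4 is therefore estimated at 100000 nM, between 30000 nM and 300000 nM, most likely again only a limit.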

Compound 4, half-maximal inhibitory concentration: 7630 nM
Estimate against measurement, compound 4: 13-fold (1.12 log units) above; measured number outside the range, below it.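

In this assay, this position proves sensitive to what it carries: replacing trifluoromethyl with ethyl gives an at least 13-fold lower number from compound 3 to compound 4 (1.11 log units; beyond the scatter), which brings the series off the assay's ceiling with a single small change. The true size of the step remains unknown, as compound 3 has only a limit, and such limits are common in this small set: the limit of > 100000 nM in this assay, at which 2 of the 4 values shown sit.

On these data alone, whether a longer chain such as propyl, or an amine, would lower the number further remains open. One pair also cannot show whether this change would have the same effect on other compounds.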